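The source may hold more compounds than are shown below. What is called first, only, known or untested is meant among the compounds shown, and "the series" means these compounds.

Measured so far in an ADME assay on the whole organism (Rattus norvegicus, strain Sprague-Dawley) for pharmacokinetics, using cassette dosing, at a dose of 0.5 mg/kg by the intravenous route; on this read-out lower numbers stand for slow clearance and higher numbers for fast clearance:
compound 1 `O[C@]1(Cc2cc(-c3cn[nH]c3)on2)CC[C@@H](Cc2ccc(C(F)(F)F)cc2)CC1` gives 4 mL/min/kg
compound 2 `O=C(c1cc(-c2ccc(=O)[nH]c2)on1)N1CCC(Cc2ccc(Cl)cc2)CC1` gives 5.4 mL/min/kg
compound 3 `O=C(Nc1ccc2[nH]c(=O)oc2c1)C(=O)N1CCN(c2ccc(Cl)cc2)CC1` gives 7.2 mL/min/kg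

Compound 3 lies within the scatter of both other compounds, so the three values are not separated. Compound 4 `O=C(Nc1ccc2[nH]c(=O)oc2c1)C(=O)N1CCN(c2ccc(C(F)(F)F)cc2)CC1` differs from compound 3 by trifluoromethyl in place of chloro on an aromatic carbon, which reads as 4-chlorophenyl to 4-(trifluoromethyl)phenyl, para to a large group. Going by the values given here, no measured pair shows this change alone, so the expectation rests on compound 3 with 7.2 mL/min/kg as its starting point. No change beyond the scatter is expected in this assay, and the estimated size is a 1.1-fold lower number from compound 3 to compound 4 (0.04 log units; within the scatter) for this replacement. Compound 4 is expected at 6.5 mL/min/kg with an estimated range of 3.2 mL/min/kg to 13 mL/min/kg in this measurement.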

Compound 4, clearance: 15.1 mL/min/kg
Beside the measured number, compound 4's estimate is 2.3-fold (0.37 log units) below it, and the stated range ends below it.
By their numbers in this assay, from the lowest: compounds 1, 2 and 3 (each within the scatter of the next); then compound 4.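

On an aromatic carbon para to a large group, the substituent matters in this assay: trifluoromethyl in place of chloro gives a 2.1-fold higher number from compound 3 to compound 4 (0.32 log units; beyond the scatter), the only step shown that lies beyond the scatter. It rests on a single pair, so it holds for the core of compound 3 and cannot yet be carried to other cores. Nothing measured here accounts for the step. Still open, as far as these compounds go, is whether a nitrile, a methoxy group or plain hydrogen at this position would read like compound 3 or like compound 4.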